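Moving Methyls: From Compound 1 to Compound 4

The source may hold more compounds than are shown below. What is called first, only, known or untested is meant among the compounds shown, and "the series" means these compounds.

Compound 1 `Cc1cc(C)cc(SCc2ccc(/C=C/C(=O)Nc3ccccc3N)cc2)c1` was tested in a functional assay on SMMC-7721 cells (Homo sapiens) for inhibition, read by CCK-8 assay, with a stated time of 72 h, tested at 8 uM (a higher number here means more inhibition of growth at the concentration tested, a lower number less inhibition of growth), and gives 7.13%, the lowest of the three numbers available. In this assay compound 2 `Cc1cc(C)cc(SCc2ccc(C(=O)Nc3ccccc3N)cc2)c1` gives 85.1%, and compound 3 `COC(=O)c1ccccc1SCc1ccc(C(=O)Nc2ccccc2N)cc1` gives 62.5%; both stand beyond the scatter above compound 1. Compound 4 `CCc1ccc(SCc2ccc(/C=C/C(=O)Nc3ccccc3N)cc2)cc1` has not yet been measured. It differs from compound 1 in one place: 4-ethylphenyl in place of 3,5-dimethylphenyl on a sulfur. For the measured compounds named here, the two compounds have the same atoms, joined differently, and no measured pair shows this change, so the expected step is small. The step that this estimate implies, a number 4.9 percentage points higher from compound 1 to compound 4 (within the scatter), is expected to lie within the scatter, with no direction claimed. Compound 4 is therefore estimated at 12%, with a range from 0% to 35%.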

Compound 4, percent growth inhibition at one concentration: 19.5%
The estimate for compound 4 lay 7.5 percentage points below the measured number; the range from low to high includes it.
By their numbers in this assay, from the lowest: compound 1; then compound 4; then compound 3; then compound 2.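

In this assay, 4-ethylphenyl in place of 3,5-dimethylphenyl on a sulfur gives a number 12.4 percentage points higher from compound 1 to compound 4 (beyond the scatter), a modest step. This shows that the group at this position matters even when the heavy atoms and ring count stay the same and only the way its carbons are joined changes. Nothing measured here bears on the cause of this step.

The compounds shown leave open whether a longer chain, such as 4-butylphenyl, or an amine on that ring would extend the step. They also leave open whether the same exchange would give a similar step on the core of compound 2.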